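Ether chain lengthening on the shared core

The source may hold more compounds than are shown below. What is called first, only, known or untested is meant among the compounds shown, and "the series" means these compounds.

Compound 1 `CCc1nncn1-c1ccc(OCc2cccc(F)c2)cc1` carries a 3-fluorophenyl on the saturated chain carbon bound to the ether oxygen; compound 2 `CCCOc1ccc(-n2cnnc2CC)cc1` has an ethyl there. In a functional assay on the whole organism (strain C57B/6) with Mus musculus as the target, in the maximal electroshock model (a lower number here means that less compound is needed, a higher number that more compound is needed for the effect), compound 1 gives 22.8 mg/kg. For compound 2 the assay reports only a limit, > 100 mg/kg, so compound 2 stands at the limit rather than at a number (the limit of > 100 mg/kg in this assay, at which 1 of the 2 values shown sits). Going by the values given here, the single measured step, an at least 4.3-fold higher number from compound 1 to compound 2 (0.64 log units; beyond the scatter), runs from a number to a limit and is itself only a bound.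

Compound 3 `CCCCOc1ccc(-n2cnnc2CC)cc1` differs from compound 2 by methyl in place of hydrogen on a saturated chain carbon, three bonds along the chain from an oxygen on an aromatic ring. Among the compounds with values here, no measured step covers this change: the one step available swaps a ring for a short chain on the same carbon and says nothing about lengthening a chain by one carbon. With compound 2 already at the limit, the expected step in this assay this assay is none beyond the scatter, a step that the limit leaves unreadable from compound 2 to compound 3. Compound 3 is therefore estimated at 150 mg/kg, with a range from 60 mg/kg to 400 mg/kg, most likely again reported only as a limit.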

Compound 3, dose for half-maximal effect: > 100 mg/kg
Compound 3: only a limit was reported; the forecaster's own chance of this, stated with the estimate: 75%; the middle value does not contradict the limit.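

In this assay compound 3 is again only a limit, > 100 mg/kg, so the methyl in place of hydrogen, three bonds along the chain from an oxygen on an aromatic ring, does not move the series back onto a measured number, and with limits at both ends the step for this change cannot be read. Against the 3-fluorophenyl ether the picture holds for a second chain, with an at least 4.3-fold higher number from compound 1 to compound 3 (0.64 log units; beyond the scatter), a bound that is beyond the scatter and matches the one for the ethyl chain, an at least 4.3-fold higher number from compound 1 to compound 2 (0.64 log units; beyond the scatter). Both simple chains shown therefore sit at the limit, and only compound 1 carries a number: the limit of > 100 mg/kg in this assay, at which 2 of the 3 values shown sit.

From the compounds shown here alone, whether the lower number of compound 1 belongs to the 3-fluorophenyl specifically or to any ring on that saturated chain carbon stays open, and a plain phenyl or a cyclohexyl there would separate the two. Also open, going by these compounds, is whether a longer chain, or a chain ending in an amine, would give a number at all in this assay, and the two limits give no order between the propyl and butyl ethers.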